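Hydrazone thiazoles in an endothelial-cell assay: removing trifluoromethyl

The source may report more compounds than this note shows. Statements on the series, on what has been measured and on what is new or still open speak of the compounds shown alone.

Measured so far:
compound 1 `COc1ccccc1-c1csc(N/N=C/c2cc(OC)c(OC)c(Br)c2Br)n1`: > 100000 nM
compound 2 `Fc1ccc(/C=N/Nc2nc(-c3ccc(C(F)(F)F)cc3)cs2)cc1F`: 79500 nM
compound 3 `COc1cc(/C=N/Nc2nc(-c3ccc(F)c(F)c3)cs2)cc(Br)c1OC`: > 100000 nM

All three were tested in an ADME assay on HUVEC cells (Homo sapiens) for inhibition, read by MTT assay, with a stated time of 48 h; a higher number here means a weaker inhibitor, a lower number a stronger inhibitor. For compound 1 the readout > 100000 nM is a limit of the assay, not a number. For compound 3 the readout > 100000 nM is likewise a limit. For the measured compounds named here, compound 2 is the only one that gives a number in this assay, 79500 nM, so it stands as the single quantified point of the set, the other two sitting at the limit of > 100000 nM in this assay, at which 2 of the 3 values shown sit. Going by the values given here, no two of the measured compounds differ from each other in one place only, so no step between measured compounds can be read off, and nothing measured here bears on the size of any single change.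

Compound 4 `Fc1ccc(/C=N/Nc2nc(-c3ccccc3)cs2)cc1F` is not yet measured. It differs from compound 2 by hydrogen in place of trifluoromethyl on an aromatic carbon. Among the compounds with values here, with no measured step to lean on, the working expectation is a step no larger than the usual scatter, and compound 2 already lies close to the limit of this assay. Compound 4 is therefore expected at about 100000 nM, within 40000 nM to 300000 nM. The expected step is a 1.3-fold higher number from compound 2 to compound 4 (0.10 log units; within the scatter), inside the scatter, though it is quite possible that the assay returns only a limit rather than a number.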

Compound 4, half-maximal inhibitory concentration: > 100000 nM
Compound 4: no number, only a limit (the forecaster's own chance of this, stated with the estimate: 50%); the middle value lies on the limit itself.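

In this assay compound 4 gives > 100000 nM, a limit of the assay and not a number. For the compounds shown here, this supplies the first step that changes one place only: hydrogen in place of trifluoromethyl on an aromatic carbon, para to a large group, gives an at least 1.2-fold higher number from compound 2 to compound 4 (0.09 log units; that floor lies within the scatter), a figure that is a floor and not a measured size. Removing trifluoromethyl therefore yields no number at this position, so the step can neither be sized nor shown to exceed the scatter, and the series offers little room to resolve such changes: the limit of > 100000 nM in this assay, at which 3 of the 4 values shown sit.

On these data alone, whether the full step from compound 2 to compound 4 is small or large remains open, as does whether the same change would behave alike on the core of compound 1 or compound 3, which carry other substituents. Also open, as far as these compounds go, is how a different group at this position, such as an amine, a carboxylic acid or a longer alkyl chain, would read in this assay, and whether any such group would give a number rather than a limit.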